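Methoxy for methylamino on the furan-2-yl core

The source may hold more compounds than are shown below. What is called first, only, known or untested is meant among the compounds shown, and "the series" means these compounds.

Compound 1 `COc1ncnc2c1c(-c1ccoc1)cn2[C@@H]1O[C@H](CO)[C@@H](O)[C@H]1O`, compound 2 `CNc1ncnc2c1c(-c1ccoc1)cn2[C@@H]1O[C@H](CO)[C@@H](O)[C@H]1O` and compound 3 `CNc1ncnc2c1c(-c1ccco1)cn2[C@@H]1O[C@H](CO)[C@@H](O)[C@H]1O` have been measured in an ADME assay on BJ cells (Homo sapiens), read by MTT assay, with a stated time of 72 h; a higher number here means a weaker inhibitor, a lower number a stronger inhibitor; compound 4 `COc1ncnc2c1c(-c1ccco1)cn2[C@@H]1O[C@H](CO)[C@@H](O)[C@H]1O` has not. In this assay compound 1 gives 28800 nM, compound 2 gives 96300 nM and compound 3 gives 5040 nM. The change methoxy in place of methylamino on an aromatic carbon has been run once among the measured compounds, and that step was a 3.3-fold lower number from compound 2 to compound 1 (0.52 log units; beyond the scatter). The two cores differ as furan-2-yl in place of furan-3-yl on an aromatic carbon, a step of a 19-fold lower number from compound 2 to compound 3 (1.28 log units; beyond the scatter). Compound 4 carries the same change, (methoxy in place of methylamino on an aromatic carbon), against the core of compound 3. Going by the values given here, compound 4 is expected to show a step of about the measured size, a 3.2-fold lower number from compound 3 to compound 4 (0.50 log units; beyond the scatter), because the only guide to this change is the step of a 3.3-fold lower number from compound 2 to compound 1 (0.52 log units; beyond the scatter). Compound 4 is therefore estimated at 1600 nM, with a range from 600 nM to 4500 nM.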

Compound 4, half-maximal inhibitory concentration: 430 nM
For compound 4 the middle estimate is 3.7-fold (0.57 log units) above the measured one; the measured number lies below the stated range.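

In this assay methoxy in place of methylamino keeps its direction on the second core, with a 12-fold lower number from compound 3 to compound 4 (1.07 log units; beyond the scatter), but not its size: the same change on two cores in this assay, a 3.3-fold lower number (0.52 log units; beyond the scatter) from compound 2 to compound 1 and a 12-fold lower number (1.07 log units; beyond the scatter) from compound 3 to compound 4, 3.5-fold (0.54 log units) apart, beyond the scatter of two such steps. Furan-2-yl in place of furan-3-yl also keeps its direction, with a 67-fold lower number from compound 1 to compound 4 (1.83 log units; beyond the scatter), and its size again differs between the two cores: the same change on two cores in this assay, a 19-fold lower number (1.28 log units; beyond the scatter) from compound 2 to compound 3 and a 67-fold lower number (1.83 log units; beyond the scatter) from compound 1 to compound 4, 3.5-fold (0.54 log units) apart, beyond the scatter of two such steps. Across these four compounds, a step measured on one core gave the direction but not the size on the other, and the data do not show why the two changes fail to add independently or whether this extends to other cores.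

Open, as far as these compounds go, is whether a dimethylamino or ethoxy group on the same aromatic carbon would follow the same course. Also open, from the compounds shown here alone, is how a thiophene in place of either furan would behave on the shared core.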